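Triazole series: swapping methoxy for trifluoromethyl on the benzyl ring

The compounds below may be only part of what the source reports. "The series", "measured", "known", "first", "only" and "open" are said of these compounds alone.

Of the compounds shown here, two carry numbers so far. Compound 1 `Fc1ccc(C(F)(F)F)cc1Cn1cnnc1-c1cccc(Cl)c1Cl` gives 912 nM in a functional assay for antagonist activity at P2X purinoceptor 7 (Homo sapiens); a lower number here means a stronger inhibitor, a higher number a weaker inhibitor. Compound 2 `COc1cccc(Cn2cnnc2-c2cccc(Cl)c2Cl)c1` gives 214 nM in this assay, the lower of the two numbers, and the gap between the two values lies beyond the usual scatter. Going by the values given here, compound 1 and compound 2 differ in two places, so no single step can be read from the pair; the values show only that compound 2 inhibits more strongly than compound 1.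

Compound 3 `FC(F)(F)c1cccc(Cn2cnnc2-c2cccc(Cl)c2Cl)c1` is the next member to be measured. It differs from compound 2 in one respect: trifluoromethyl in place of methoxy on an aromatic carbon. The trifluoromethyl group is shared with compound 1, whose value 912 nM sits well above that of compound 2, but compound 1 also carries a fluorine that compound 3 lacks, so the comparison is indirect. A moderate step upward in this assay is expected from compound 2 to compound 3, of the size a 2.3-fold higher number from compound 2 to compound 3 (0.37 log units; beyond the scatter). For compound 3 the estimate in this assay is 500 nM, with a range from 150 nM to 1600 nM.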

Compound 3, half-maximal inhibitory concentration: 1290 nM
Estimate against measurement, compound 3: 2.6-fold (0.41 log units) below, within the range that was stated.
By their numbers in this assay, from the lowest: compound 2; then compounds 1 and 3 (each within the scatter of the next).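

In this assay, going by these compounds alone, the one-place change at this aromatic carbon, trifluoromethyl in place of methoxy, gives a 6.0-fold higher number from compound 2 to compound 3 (0.78 log units; beyond the scatter) and provides the first readable step: the position responds to the group it carries, and of these two groups methoxy gives the stronger inhibitor. Hydrogen in place of fluoro on an aromatic carbon gives a 1.4-fold higher number from compound 1 to compound 3 (0.15 log units; within the scatter) and this step stays inside the scatter, so this pair shows no readable effect of that fluoro, and compound 1 and compound 3 cannot be told apart here. No measurement at hand bears on the reason for either step.

From the compounds shown here alone, only methoxy and trifluoromethyl have been compared at this aromatic carbon, so it remains open whether the step reflects the loss of methoxy or the arrival of trifluoromethyl. Plain hydrogen, chloro, methyl, ethoxy or an amine at the same carbon would help to separate the two readings, and the two chloro groups of the shared core remain untested by any step shown.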